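Solubility of a sulfonamide series: swapping a ring-nitrogen substituent

The source may report more compounds than this note shows. Statements on the series, on what has been measured and on what is new or still open speak of the compounds shown alone.

Measured so far:
- compound 1, `O=S(=O)(NC1CCN(S(=O)(=O)c2ccccc2)CC1)c1cc(S(=O)(=O)c2ccccc2)ccc1C(F)(F)F`: 25000 nM
- compound 2, `CC(C)(C)OC(=O)N1CC[C@@H](C(=O)N2CCC(NS(=O)(=O)c3cc(S(=O)(=O)c4ccccc4)ccc3C(F)(F)F)CC2)C1`: 12500 nM

In a physicochemical assay for solubility (a lower number here means a less soluble compound, a higher number a more soluble compound), compound 1 gives 25000 nM. Compound 2 gives 12500 nM in this assay, and the two numbers lie within the usual scatter of each other, so neither compound can be set apart from the other on solubility. Compound 3, `O=C(C1CCNCC1)N1CCC(NS(=O)(=O)c2cc(S(=O)(=O)c3ccccc3)ccc2C(F)(F)F)CC1`, has not yet been measured in this assay. It differs from compound 1 in one place: (piperidin-4-yl)carbonyl in place of phenylsulfonyl on an amine nitrogen in a ring. For the measured compounds named here, no measured pair shows a change of this kind, so the expected size of the step rests only on the two values known and on the change itself. Compound 3 is expected to give a higher number in this assay than compound 1, with a step of a 6.0-fold higher number from compound 1 to compound 3 (0.78 log units; beyond the scatter) well beyond the scatter. The estimate for compound 3 is 150000 nM, within a range of 40000 nM to 500000 nM.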

Compound 3, solubility: 100000 nM
The estimate for compound 3 lay 1.5-fold (0.18 log units) above the measured number; measured number inside the range.
By their numbers in this assay, from the lowest: compounds 2 and 1 (each within the scatter of the next); then compound 3.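

In this assay, the substituent on the amine nitrogen in a ring now proves able to move the read-out: (piperidin-4-yl)carbonyl in place of phenylsulfonyl gives a 4.0-fold higher number from compound 1 to compound 3 (0.60 log units; beyond the scatter), whereas compound 1 and compound 2 could not be told apart. The group on the carbonyl carbon also counts, since piperidin-4-yl in place of 1-(tert-butoxycarbonyl)pyrrolidin-3-yl gives an 8.0-fold higher number from compound 2 to compound 3 (0.90 log units; beyond the scatter), so the carbonyl link alone does not set the number. No measurement shown here accounts for either step.

On these data alone, what remains open is how much of the rise belongs to the carbonyl and how much to the ring bearing the nitrogen. An acetyl group or a cyclohexylcarbonyl group on the same nitrogen would separate these two parts of the change.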